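A few compounds are considered here, and "the series" means these few. Any claim that something is new, unique, unknown or untested is made for them only; others in the source may bear on it.

Measured compounds:
Compound 1, `CCCNS(=O)(=O)c1ccc(Nc2ncc3c(n2)N(C2CCCC2)[C@H](CC)C(=O)N3C)cc1`, gives 548 nM in a functional assay on K562 cells (Homo sapiens) for antiproliferative activity, read by CCK-8 assay, with a stated time of 72 h; on this read-out higher numbers stand for weaker inhibition of growth and lower numbers for stronger inhibition of growth.
Compound 2, `CCC1C(=O)N(C)c2cnc(-n3ccc4cc(C(N)=O)ccc43)nc2N1c1ccn(C)n1`, gives 31300 nM in this assay.
Compound 3, `CCC1C(=O)N(C)c2cnc(-n3ccc4cc(C(=O)NC)ccc43)nc2N1c1ccn(C)n1`, gives 13300 nM in this assay.

Of these three numbers compound 1 stands lowest. Its nearest neighbour is compound 3, and the gap between compound 1 and compound 3 lies beyond the scatter, as does the wider gap between compound 1 and compound 2. Compounds 2 and 3 share a core different from that of compound 1, so their relation to compound 1 is seen only through their values.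

Compound 4, `CC[C@@H]1C(=O)N(C)c2cnc(Nc3ccc(S(N)(=O)=O)cc3)nc2N1C1CCCC1`, is not yet measured. Its difference from compound 1 is hydrogen in place of propyl on a sulfonamide nitrogen.

Among the measured compounds shown here, only one measured step touches the question of an alkyl group on a nitrogen of this kind: a 2.4-fold lower number from compound 2 to compound 3 (0.37 log units; beyond the scatter), where the alkyl group enters rather than leaves, and on an amide-type nitrogen rather than a sulfonamide nitrogen. Taken as a loose guide in reverse, it suggests that losing the propyl group might raise the number by a modest margin, though the sulfonamide setting is untested. The author therefore expects compound 4 to show a modest weakening, a 2.0-fold higher number from compound 1 to compound 4 (0.30 log units; within the scatter), and estimates for compound 4 a value of 1100 nM, within a range from 350 nM to 3500 nM.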

Compound 4, concentration for 50% growth inhibition: 470 nM
The estimate for compound 4 lay 2.3-fold (0.37 log units) above the measured number, within the range that was stated.
By their numbers in this assay, from the lowest: compounds 4 and 1 (each within the scatter of the next); then compound 3; then compound 2.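

In this assay, replacing the propyl group on the sulfonamide nitrogen with hydrogen gives a 1.2-fold lower number from compound 1 to compound 4 (0.07 log units; within the scatter), so on this core the read-out does not separate the propylsulfamoyl group from the bare sulfamoyl group. The earlier compounds shown here offered only a change on an amide-type nitrogen on a different core, a 2.4-fold lower number from compound 2 to compound 3 (0.37 log units; beyond the scatter), and that step, which lies beyond the scatter, does not carry over to the sulfonamide nitrogen of compound 1 and compound 4. No supporting measurement is available to explain this result.

Compound 1 and compound 4 show only that propyl and hydrogen on this nitrogen cannot be told apart in this assay, leaving open whether the same would hold for a longer chain or for a chain ending in an amine or a carboxylic acid. This single pair also leaves open whether the same change would behave alike on the sulfonamide nitrogen of another core.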